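The compounds below may be only part of what the source reports. "The series", "measured", "known", "first", "only" and "open" are said of these compounds alone.

Compound 3 `CSc1nnc(Cc2ccccc2Oc2ccccc2)[nH]1` carries a methylsulfanyl group on the shared core, and in a functional assay on the whole organism (strain NMRI) with Mus musculus as the target, with a stated time of 60 min, at a dose of 10 mg/kg by the intraperitoneal route (on this read-out higher numbers stand for a stronger effect at the one dose given and lower numbers for a weaker effect), compound 3 gives 133%. Among the three compounds measured, compound 3 has the lowest number, yet both gaps to the others lie within the usual scatter. Compound 2 `S=c1[nH]nc(Cc2ccc(Cl)cc2Oc2ccccc2Cl)[nH]1` gives 139%. Compound 1 `S=c1[nH]nc(Cc2ccccc2Oc2ccccc2)[nH]1` differs from compound 3 only in the sulfur-bearing part of the core, and compound 1 gives 142%. Going by the values given here, the single step measured between two compounds that differ in one place is a number 9 percentage points lower from compound 1 to compound 3 (within the scatter), and that step stays within the scatter.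

Compound 4 `CCSc1nnc(Cc2ccccc2Oc2ccccc2)[nH]1` takes the series one step further: methyl in place of hydrogen on a saturated chain carbon bound to a sulfur. Among the compounds with values here, no measured pair shows what lengthening the chain on the sulfur does to this read-out; the one step that was measured concerns a different change, from the core of compound 1 to the methylsulfanyl group of compound 3, and it was small. With nothing pointing in either direction, the expected step is a number 3 percentage points lower from compound 3 to compound 4 (within the scatter), that is, no change beyond the scatter. Compound 4 is therefore estimated at 130%, with a range from 110% to 150%.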

Compound 4, a percentage reported as activity, at one dose (the size of the read-out at that dose, not a potency): 142%
The estimate for compound 4 lay 12 percentage points below the measured number, within the range that was stated.
By their numbers in this assay, from the lowest: compounds 3, 2, 1 and 4 (each within the scatter of the next).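

Going by these compounds alone, replacing methylsulfanyl with ethylsulfanyl gives a number 9 percentage points higher from compound 3 to compound 4 (within the scatter) in this assay, and this is the first reading at this place on the sulfur chain. Within the data shown here, the earlier step showed only that the core of compound 1 could give way to a methylsulfanyl group, whereas this one shows that the group on the sulfur can also grow by one methyl with no shift beyond the scatter, at the one dose given. No measurement of any property of these compounds is available to account for this result.

This single step leaves open how far the chain on the sulfur can grow, and whether a propyl or butyl chain, or a sulfur chain ending in an amine or a carboxylic acid, would keep the read-out in the same range. It also leaves open whether ethylsulfanyl would behave the same way on the two chlorine-bearing rings of compound 2, and, as the read-out comes from one dose, how the potencies of these compounds compare.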